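This account rests on a few compounds, and the source may have more. Where it says the series, first, only, none or still open, it means among the compounds named here.

Measured so far in a functional assay on HeLa cells (Homo sapiens) for inhibition, read by CCK-8 assay, with a stated time of 48 h; a lower number here means a stronger inhibitor, a higher number a weaker inhibitor:
- compound 1 `O=C(NCCNS(=O)(=O)c1ccc(-c2ccccc2O[C@H]2CC[C@@H](O)CC2)s1)Nc1ccc([N+](=O)[O-])cc1` gives > 20000 nM, a limit of the assay
- compound 2 `O=C(NCCNS(=O)(=O)c1ccc(-c2ccccc2O[C@H]2CC[C@H](O)CC2)s1)Nc1ccc([N+](=O)[O-])cc1` gives 10500 nM
- compound 3 `O=[N+]([O-])c1ccc(NC(=S)NCCNS(=O)(=O)c2ccc(-c3ccccc3O[C@H]3CC[C@@H](O)CC3)s2)cc1` gives > 20000 nM, a limit of the assay

Compound 3 stands at a limit and not at a number, and compound 1 shares it (the limit of > 20000 nM in this assay, at which 2 of the 3 values shown sit). The next compound is compound 4 `O=[N+]([O-])c1ccc(NC(=S)NCCNS(=O)(=O)c2ccc(-c3ccccc3OCc3ccccc3)s2)cc1`, and the change is benzyl in place of 4-hydroxycyclohexyl on an oxygen on an aromatic ring. In words, this is benzyl in place of 4-hydroxycyclohexyl on an oxygen on an aromatic ring.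

Within the data shown here, two measured steps bear on this, both only loosely. Among the measured compounds shown here, the one at the same group is an at least 1.9-fold lower number from compound 1 to compound 2 (0.27 log units; that floor lies within the scatter), and the whole of that change is the fact that compounds 1 and 2 differ only in the configuration as drawn. The other is a step that the two limits leave unreadable from compound 1 to compound 3, which lies at a different place and gives no size. For the measured compounds named here, no measured step replaces the 4-hydroxycyclohexyl group itself, so the data set no firm size for this change.

Going by the values given here, the only number is the one for compound 2 at 10500 nM, and the expectation leans on it. A modest move to a lower number is expected, though a reading at the limit remains quite possible. The expected step is an at least 1.6-fold lower number from compound 3 to compound 4 (0.22 log units; that floor lies within the scatter). For compound 4 the estimate is 12000 nM, with an expected range from 3000 nM to 40000 nM.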

Compound 4, half-maximal inhibitory concentration: 7100 nM
Compound 4: middle estimate off by 1.7-fold (0.23 log units), on the high side, and the stated range covers the measured number.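

Replacing 4-hydroxycyclohexyl with benzyl on the oxygen on the aromatic ring gives, in this assay, an at least 2.8-fold lower number from compound 3 to compound 4 (0.44 log units; beyond the scatter), so this position now has a step that lies beyond the scatter. Before this, the only readable step at this group was a change of configuration alone, an at least 1.9-fold lower number from compound 1 to compound 2 (0.27 log units; that floor lies within the scatter), whose floor lies within the scatter, while the step from compound 1 to compound 3 cannot be read. Compound 3 carries a limit and not a number, and the new step is a floor and not a full size because of that limit: the limit of > 20000 nM in this assay, at which 2 of the 4 values shown sit.

The change swaps a non-aromatic ring for an aromatic one, and it also removes a hydrogen-bond donor, a hydrogen-bond acceptor and two defined stereocentres, and the compounds shown do not separate these differences. Open questions are how a plain cyclohexyl or a cyclohexylmethyl group on this oxygen would read, which would keep the ring non-aromatic without the hydroxy group, and whether a pyridylmethyl group would keep the step seen with benzyl.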